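The source may hold more compounds than are shown below. What is called first, only, known or untested is meant among the compounds shown, and "the series" means these compounds.

Compound 1 `CS(=O)(=O)c1ccc(C(=O)NCCC(=O)N2CCc3ccccc3C2)cc1[N+](=O)[O-]` gives > 60000 nM in an assay on isolated protein for inhibition of thyroid hormone receptor beta (Homo sapiens), read by fluorescence polarization (on this read-out lower numbers stand for stronger inhibition and higher numbers for weaker inhibition), a limit of the assay rather than a number.
Compound 2 `CC(C)N(C(=O)C1CCN(C(=O)c2ccc(S(C)(=O)=O)c([N+](=O)[O-])c2)CC1)C(C)C` gives > 60000 nM in this assay, again a limit of the assay rather than a number.

Compound 2 therefore stands at the top limit of the range shown, and so does the only other measured compound, as the limit of > 60000 nM in this assay, at which 2 of the 2 values shown sit, records. Among the compounds with values here, neither value is a number, so no measured step between the two can be given; both merely show a lack of measurable inhibition. Compound 3 `CS(=O)(=O)c1ccc(C(=O)N2CCC(C(=O)N3CCc4ccccc43)CC2)cc1[N+](=O)[O-]` differs from compound 2 in one place: 2,3-dihydro-1H-indol-1-yl in place of diisopropylamino on a carbonyl carbon. Since compound 2 sits at a limit, a step from it in this assay can only be judged as a drop into the measurable range or none at all, and none beyond the scatter is expected. Compound 3 is estimated to give 60000 nM in this assay, with a range from 15000 nM to 200000 nM, most probably returned as a limit; the expected step is a number no higher from compound 2 to compound 3 (the limit leaves the size open).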

Compound 3, half-maximal inhibitory concentration: > 60000 nM
Compound 3 ended at the assay's limit; the forecaster's own chance of this, stated with the estimate: 80%; the middle value lies on the limit itself.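

No step can be read between compound 2 and compound 3, since both end at a limit of the assay and not at a number. The compounds shown leave open what, if anything, on the shared core would bring inhibition into the measurable range of this assay.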